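Ring Opening Step Repeated on a Second Amide Core

This account rests on a few compounds, and the source may have more. Where it says the series, first, only, none or still open, it means among the compounds named here.

Compound 1 `O=C(CCCCC1CCSS1)Nc1ccc(Cl)cn1` and compound 3 `O=C(CCCCC(S)CCS)Nc1ccc(Cl)cn1` share one core and differ in one place: a group of 5 heavy atoms (3 carbon, 2 sulfur; no ring) in place of a group of 5 heavy atoms (3 carbon, 2 sulfur; one five-membered non-aromatic ring with 2 hetero atoms), on a saturated chain carbon, four bonds along the chain from a carbonyl carbon. In a functional assay on Bel-7402 cells (Homo sapiens) for inhibition, read by MTT assay, with a stated time of 24 h, tested at 1 ug/mL (on this read-out lower numbers stand for less inhibition of growth and higher numbers for more inhibition of growth at the one concentration tested), compound 1 gives 7.44%, and compound 3 gives 2.34%, a step of a number 5.1 percentage points lower from compound 1 to compound 3 (within the scatter). Compound 2 `O=C(CCCCC1CCSS1)Nc1cccc2ccccc12` carries a different core; how its core differs from that of compound 1 is not broken down here. In this assay compound 2 gives 9.55%. Compound 4 `O=C(CCCCC(S)CCS)Nc1cccc2ccccc12` is built from compound 2 by the same change, (a group of 5 heavy atoms (3 carbon, 2 sulfur; no ring) in place of a group of 5 heavy atoms (3 carbon, 2 sulfur; one five-membered non-aromatic ring with 2 hetero atoms), on a saturated chain carbon, four bonds along the chain from a carbonyl carbon). The step from compound 2 to compound 4 is expected to be a number 4.6 percentage points lower from compound 2 to compound 4 (within the scatter), because the earlier step of a number 5.1 percentage points lower from compound 1 to compound 3 (within the scatter) stayed within the scatter and the place of the change is the same. Compound 4 is therefore estimated at 5%, between 0% and 12%.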

Compound 4, percent growth inhibition at one concentration: 0.69%
Beside the measured number, compound 4's estimate is 4.3 percentage points above it; low and high end bracket the measured number.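

In this assay, putting the open 1,3-disulfanylpropyl group in place of the ring gives a number 8.9 percentage points lower from compound 2 to compound 4 (within the scatter). Set beside the same change on the core of compound 1, the two steps cannot be told apart: the same change on two cores in this assay, a number 5.1 percentage points lower (within the scatter) from compound 1 to compound 3 and a number 8.9 percentage points lower (within the scatter) from compound 2 to compound 4, 3.8 percentage points apart, within the scatter of two such steps This agrees with the change carrying over from one core to the other, but with each step inside the scatter, it does not show that opening the ring alters growth inhibition at all, and two cores make no rule for the series.

Still open, as far as these compounds go, is whether an amine, a carboxylic acid or a longer chain at the same place would give a step beyond the scatter. Also open, from the compounds shown here alone, is how these compounds compare at other concentrations.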